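Bromo to Chloro on Two Related Cores

The compounds below may be only part of what the source reports. "The series", "measured", "known", "first", "only" and "open" are said of these compounds alone.

Compound 1, `COC(=O)[C@@]1(C)CCC=C2[C@@H]1CC[C@@H](C)[C@]2(C)Cc1c(C)[nH]c2c(Br)cccc12`, gives 22000 nM in a functional assay on HeLa cells (Homo sapiens) for inhibition, read by sulforhodamine B assay, with a stated time of 48 h; a lower number here means a stronger inhibitor of growth, a higher number a weaker inhibitor of growth. Compound 2, `COC(=O)[C@@]1(C)CCC=C2[C@@H]1CC[C@@H](C)[C@]2(C)Cc1c(C)[nH]c2c(Cl)cccc12`, gives 17000 nM in this assay. Compound 3, `COC(=O)[C@@]1(C)CC[C@@H]2C3=C1CC[C@@H](C)[C@]3(C)C[C@@H]1c3cc(Br)ccc3N[C@H]21`, gives 25000 nM in this assay.

The step from compound 1 to compound 2 is chloro in place of bromo on an aromatic carbon. That change gave a 1.3-fold lower number from compound 1 to compound 2 (0.11 log units; within the scatter), so the two halogens left the growth-inhibiting number essentially where it was. Compound 3 carries a different core, and the difference between the two cores is not broken down here; its value in this assay sits within the scatter of both compound 1 and compound 2.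

Compound 4, `COC(=O)[C@@]1(C)CC[C@@H]2C3=C1CC[C@@H](C)[C@]3(C)C[C@@H]1c3cc(Cl)ccc3N[C@H]21`, has not yet been measured. It differs from compound 3 by chloro in place of bromo on an aromatic carbon. For the measured compounds named here, this is the same kind of change as the one from compound 1 to compound 2, though the surroundings are not identical: in compound 2 the ring belongs to a fused system of two rings and the halogen sits ortho to a fused ring and meta to a fused ring, whereas in compound 4 the ring belongs to a fused system of five rings and the halogen sits meta to a fused ring and para to a fused ring.

Since the earlier exchange gave only a 1.3-fold lower number from compound 1 to compound 2 (0.11 log units; within the scatter), compound 4 is expected to show a step of about a 1.3-fold lower number from compound 3 to compound 4 (0.10 log units; within the scatter) from compound 3, within the scatter. Compound 4 is therefore estimated at 20000 nM in this assay, with a likely range from 8000 nM to 50000 nM.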

Compound 4, concentration for 50% growth inhibition: 23000 nM
Compound 4: middle estimate off by 1.2-fold (0.06 log units), on the low side; the range from low to high includes it.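

On the core of compound 3, chloro in place of bromo on an aromatic carbon gave a 1.1-fold lower number from compound 3 to compound 4 (0.04 log units; within the scatter) in this assay, leaving the number essentially where it was. Set beside the earlier exchange, the new step agrees with it, and on these two cores the change carried over as a step that stays inside the scatter: the same change on two cores in this assay, a 1.3-fold lower number (0.11 log units; within the scatter) from compound 1 to compound 2 and a 1.1-fold lower number (0.04 log units; within the scatter) from compound 3 to compound 4, 1.2-fold (0.08 log units) apart, within the scatter of two such steps. This shows only that exchanging these two halogens produced no readable step in this assay on either core; it does not show that the exchange would stay as small on any other core or in any other assay, and the agreement is between two steps that are both within the scatter, not between two clear effects.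

The compounds shown leave open whether a group other than a halogen on the aromatic ring, such as methoxy, an amine or a hydrogen alone, would move the number on either core. They also leave open what would happen if the methyl ester that all four compounds carry gave way to a carboxylic acid or an amide.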